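A few compounds are considered here, and "the series" means these few. Any claim that something is new, unique, unknown or untested is made for them only; others in the source may bear on it.

Measured so far:
compound 1 `Cc1ccc(SCc2ccc(/C=C/C(=O)Nc3ccccc3N)cc2)cc1` — 21.7%
compound 2 `Nc1ccccc1NC(=O)c1ccc(CSc2ccc(Br)cc2)cc1` — 38.2%

In a functional assay on HeLa cells (Homo sapiens) for inhibition, read by CCK-8 assay, with a stated time of 72 h, tested at 8 uM (on this read-out higher numbers stand for more inhibition of growth at the one concentration tested and lower numbers for less inhibition of growth), compound 2 stands highest of the two numbers; compound 1 sits a gap below it that is beyond the scatter. Compound 3 `Nc1ccccc1NC(=O)c1ccc(CSc2cccc(F)c2)cc1` has not yet been measured. It differs from compound 2 in one place: 3-fluorophenyl in place of 4-bromophenyl on a sulfur. Among the compounds with values here, no measured pair shows this change, so its size is not known from the series. A small downward step, if any, is expected for a number 5.2 percentage points lower from compound 2 to compound 3 (within the scatter), likely within the scatter. Compound 3 is therefore estimated at 33%, within 16% to 50%.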

Compound 3, percent growth inhibition at one concentration: 78.4%
The estimate for compound 3 lay 45.4 percentage points below the measured number; measured number outside the range, above it.
By their numbers in this assay, from the lowest: compound 1; then compound 2; then compound 3.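

In this assay, 3-fluorophenyl in place of 4-bromophenyl on a sulfur gives a number 40.2 percentage points higher from compound 2 to compound 3 (beyond the scatter), so the aryl group on this sulfur strongly affects growth inhibition while the rest of the structure stays fixed. Within the data shown here, this is the first single-place step, and it shows that two groups of equal heavy-atom count can differ widely here. Nothing available accounts for the size of this step.

The halogen and its ring position change together, so either could carry the step; 4-fluorophenyl and 3-bromophenyl would separate them. From the compounds shown here alone, how an aminophenyl or carboxyphenyl group would behave on this sulfur remains open.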